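A few compounds are considered here, and "the series" means these few. Any claim that something is new, unique, unknown or untested is made for them only; others in the source may bear on it.

Measured so far:
- compound 1, `COc1ccc(/C=N/Nc2nc3ccccc3nc2Cc2ccccc2)cc1OC`: 460000 nM
- compound 2, `C/C(=N\Nc1nc2ccccc2nc1Cc1ccccc1)c1ccc(O)cc1`: 8400000 nM

Compound 2 carries the higher of the two numbers recorded in an assay on isolated protein for inhibition of Amine oxidase [flavin-containing] B (Homo sapiens), read by spectrophotometry; on this read-out lower numbers stand for stronger inhibition and higher numbers for weaker inhibition; compound 1 sits well below it, and the gap between the two lies beyond the usual scatter of this read-out. Both compounds share the same core, and compound 1 differs from compound 2 in more than one place, so no single structural step can be read between them.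

Compound 3, `C/C(=N\Nc1nc2ccccc2nc1Cc1ccccc1)c1ccc(C)cc1`, is not yet measured. It differs from compound 2 by methyl in place of hydroxy on an aromatic carbon; cut one bond further out, the change reads 4-hydroxyphenyl to 4-methylphenyl. Going by the values given here, no measured pair isolates this exchange, so there is no step to lean on. The expectation rests on the weak standing of compound 2, 8400000 nM, which leaves room downward, and on the lower number of compound 1, which carries no hydroxy group. A modest drop in this assay is expected, of the size a 2.8-fold lower number from compound 2 to compound 3 (0.45 log units; beyond the scatter), though a step within the scatter would not surprise.

Compound 3 is therefore estimated at 3000000 nM, within 800000 nM to 15000000 nM.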

Compound 3, half-maximal inhibitory concentration: 740000 nM
Compound 3: the middle estimate sits 4.1-fold (0.61 log units) above what was measured, and the stated range ends above it.
By their numbers in this assay, from the lowest: compounds 1 and 3 (each within the scatter of the next); then compound 2.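

In this assay, replacing hydroxy with methyl on the aromatic carbon para to a large group gives an 11-fold lower number from compound 2 to compound 3 (1.06 log units; beyond the scatter). This is a large step and the only one in the series that isolates a single place. It shows that this position is not indifferent to the group it carries: with the rest of the structure unchanged, 4-methylphenyl gives a much lower number than 4-hydroxyphenyl. No evidence on the origin of the step accompanies this pair, which gives its size and direction only.

Going by these compounds alone, with only two groups compared at this position, the pair cannot separate what leaving hydroxy contributes from what entering methyl contributes. On these data alone, it remains open how a methoxy group, an amine, a fluorine atom or a longer chain such as ethyl would stand on the same carbon, and whether the same exchange would give a step of similar size in the setting of compound 1, which differs from compound 3 in more than one place.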